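Notes on compound 4: dinitrophenyl for ethoxyphenyl

This account rests on a few compounds, and the source may have more. Where it says the series, first, only, none or still open, it means among the compounds named here.

Three compounds of the series have been run in a functional assay on MCF7 cells (Homo sapiens) for antiproliferative activity, read by MTT assay, with a stated time of 48 h; a lower number here means a stronger inhibitor, a higher number a weaker inhibitor. Compound 1 `N#CC1=C(N)Oc2c(c3nc4ccccc4nc3c3ccccc23)C12C(=O)N(Cc1cnnn1-c1cccc(Cl)c1)c1ccccc12` gives 43600 nM in this assay. Compound 2 `N#CC1=C(N)Oc2c(c3nc4ccccc4nc3c3ccccc23)C12C(=O)N(Cc1cnnn1-c1cc(Cl)ccc1Cl)c1ccccc12` is reported in this assay only as a limit, > 50000 nM. Compound 3 `CCOc1ccc(-n2nncc2CN2C(=O)C3(C(C#N)=C(N)Oc4c(N)cc5nc6ccccc6nc5c43)c3ccccc32)cc1` gives 26800 nM in this assay, the lowest of the two numbers, with compound 1 the nearest and within the scatter of it.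

Compound 4 `N#CC1=C(N)Oc2c(N)cc3nc4ccccc4nc3c2C12C(=O)N(Cc1cnnn1-c1ccc([N+](=O)[O-])cc1[N+](=O)[O-])c1ccccc12` is not yet measured. It differs from compound 3 by 2,4-dinitrophenyl in place of 4-ethoxyphenyl on an aromatic nitrogen. For the measured compounds named here, the only measured step, an at least 1.1-fold higher number from compound 1 to compound 2 (0.05 log units; that floor lies within the scatter), concerns a chloro in place of hydrogen on an aromatic carbon and does not touch the group on the aromatic nitrogen, so it gives little guidance here. Compound 2 sits at the limit of > 50000 nM in this assay, at which 1 of the 3 values shown sits. Going by the values given here, nothing among the measured compounds shows an exchange of the aryl group on the aromatic nitrogen. No step beyond the scatter is therefore expected, a 1.1-fold higher number from compound 3 to compound 4 (0.05 log units; within the scatter). Compound 4 is estimated at 30000 nM, between 10000 nM and 50000 nM, with a real chance that this assay reports only a limit.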

Compound 4, half-maximal inhibitory concentration: 20900 nM
Estimate against measurement, compound 4: 1.4-fold (0.16 log units) above, within the range that was stated.
By their numbers in this assay, from the lowest: compounds 4, 3 and 1 (each within the scatter of the next, the first and the last beyond it). At a limit, above all of these: compound 2.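

In this assay, for the compounds shown here, 2,4-dinitrophenyl in place of 4-ethoxyphenyl on the aromatic nitrogen gives a 1.3-fold lower number from compound 3 to compound 4 (0.11 log units; within the scatter), the first measured step at this position. The entering group has more heavy atoms and more hydrogen-bond acceptors than the leaving group, yet this exchange does not separate compound 3 from compound 4. Nothing measured here accounts for this result.

Whether any group at this position can move the value beyond the scatter remains open: a phenyl ring bearing an amine or a carboxylic acid, or a longer alkyl chain in place of the aryl ring, lies outside the compounds shown. On these data alone, compound 1 and compound 2 differ from compound 3 and compound 4 in the core as well, so the effect of their chlorinated aryl groups on the core of compound 3 also remains open.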